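Swapping the Aryl Group on the Sulfonyl Sulfur

The source may hold more compounds than are shown below. What is called first, only, known or untested is meant among the compounds shown, and "the series" means these compounds.

Compound 1, `O=C(/C=C/c1ccccc1)c1ccc(N2CCN(S(=O)(=O)c3ccc4ccccc4c3)CC2)cc1`: in a functional assay on the whole organism (strain Kunming) for inhibition, with Mus musculus as the target, with a stated time of 1 h, at a dose of 40 mg/kg by the oral route (a lower number here means less inhibition, a higher number more inhibition at the dose given (going by the name of the read-out)), compound 1 gives 35%.
Compound 2, `O=C(/C=C/c1ccccc1)c1ccc(N2CCN(S(=O)(=O)c3ccc(Br)cc3)CC2)cc1`: in this assay compound 2 gives 47.4%.
Compound 3, `O=C(/C=C/c1ccccc1)c1ccc(N2CCN(S(=O)(=O)c3ccc(C(F)(F)F)cc3)CC2)cc1`: in this assay compound 3 gives 47.9%.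

Compound 3 holds the highest of the three numbers, but its nearest neighbour, compound 2, lies within the scatter of it, so these two cannot be ordered; only compound 1 sits clearly lower, as the step of a number 12.9 percentage points higher from compound 1 to compound 3 (beyond the scatter) shows. The unmeasured compound 4, `COc1ccc(S(=O)(=O)N2CCN(c3ccc(C(=O)/C=C/c4ccccc4)cc3)CC2)cc1OC`, differs from compound 3 in one place: 3,4-dimethoxyphenyl in place of 4-(trifluoromethyl)phenyl on a sulfonyl sulfur. For the measured compounds named here, two measured steps bear on changes at this position. Replacing the naphthalen-2-yl group on the sulfonyl sulfur by a 4-bromophenyl group gave a number 12.4 percentage points higher from compound 1 to compound 2 (beyond the scatter), and replacing it by a 4-(trifluoromethyl)phenyl group gave a number 12.9 percentage points higher from compound 1 to compound 3 (beyond the scatter); exchanging bromo for trifluoromethyl on the aromatic carbon gave a number 0.5 percentage points higher from compound 2 to compound 3 (within the scatter). Going by the values given here, no measured compound carries a 3,4-dimethoxyphenyl group, so the direction of the step in this assay cannot be read from a matching pair. Because steps at this position have been as large as a number 12.9 percentage points higher from compound 1 to compound 3 (beyond the scatter), compound 4 is expected to fall somewhere within the span the three measured compounds cover, most likely near its middle. Compound 4 is therefore estimated at 42%, with a range from 28% to 56%, which means an expected step of a number 5.9 percentage points lower from compound 3 to compound 4 (within the scatter).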

Compound 4, a percentage reported as inhibition, in the whole organism at one dose (the size of the read-out at that dose, not a potency): 55.5%
For compound 4 the middle estimate is 13.5 percentage points below the measured one; low and high end bracket the measured number.
By their numbers in this assay, from the lowest: compound 1; then compounds 2, 3 and 4 (each within the scatter of the next).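

In this assay, the place on the sulfonyl sulfur takes a 3,4-dimethoxyphenyl group, with 2 hydrogen-bond acceptors, in place of a 4-(trifluoromethyl)phenyl group, with 0, and the result is a number 7.6 percentage points higher from compound 3 to compound 4 (within the scatter); the exchange for 4-bromophenyl likewise gives a number 8.1 percentage points higher from compound 2 to compound 4 (within the scatter). For the compounds shown here, the three substituted phenyl groups therefore cannot be ordered among themselves, so bringing in oxygen in place of fluorine or bromine makes no readable difference here, while the separation from the naphthalen-2-yl group grows to a number 20.5 percentage points higher from compound 1 to compound 4 (beyond the scatter), the largest step seen at this place so far. Nothing on hand gives a reason for this behaviour at the sulfonyl sulfur.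

The compounds shown leave open whether both methoxy groups are needed, since neither a 4-methoxyphenyl group nor a plain phenyl group stands among them, and what an amine or a carboxylic acid on the aryl ring would do in this assay. They also leave open how far these readings hold once the shared core is changed, as all four compounds differ only in the aryl group on the sulfonyl sulfur.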